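A few compounds are considered here, and "the series" means these few. Any claim that something is new, unique, unknown or untested is made for them only; others in the source may bear on it.

Compound 1 `CN(C)c1ccc(/C=C(/SCc2ccc(Br)cc2)C(=O)c2ccc(C(=O)O)cc2)cc1`: 50000 nM
Compound 2 `O=C(O)c1ccc(C(=O)/C(=C\c2ccc(Br)c([N+](=O)[O-])c2)SCc2ccc(Br)cc2)cc1`: 1000 nM

In a functional assay on DU-145 cells (Homo sapiens) for inhibition, read by trypan blue exclusion, with a stated time of 96 h (on this read-out lower numbers stand for stronger inhibition of growth and higher numbers for weaker inhibition of growth), compound 1 gives 50000 nM, the higher of the two numbers and so the weaker inhibition of growth. Compound 3 `CN(C)c1ccc(/C=C(/SCc2ccc(F)cc2)C(=O)c2ccc(C(=O)O)cc2)cc1` differs from compound 1 by fluoro in place of bromo on an aromatic carbon, para to a large group. Among the compounds with values here, the only measured step, a 50-fold lower number from compound 1 to compound 2 (1.70 log units; beyond the scatter), is large but changes a different place, so no measured step tests this swap. In this assay, the expected change is small, a 1.3-fold lower number from compound 1 to compound 3 (0.10 log units; within the scatter), with no shift beyond the scatter expected in either direction. For compound 3 the estimated value is 40000 nM, with an expected range of 12000 nM to 100000 nM.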

Compound 3, concentration for 50% growth inhibition: 10000 nM
The estimate for compound 3 lay 4.0-fold (0.60 log units) above the measured number, outside the stated range (below it).
By their numbers in this assay, from the lowest: compound 2; then compound 3; then compound 1.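

In this assay, the halogen on the benzyl group turns out to matter: fluoro in place of bromo gives a 5.0-fold lower number from compound 1 to compound 3 (0.70 log units; beyond the scatter). The earlier step concerned only the 4-(dimethylamino)phenyl group, so this is a second place on the molecule where one change moves the number, here toward stronger inhibition of growth. Nothing available explains why this swap has this effect.

As far as these compounds go, it remains open how chloro, methoxy or plain hydrogen would compare at this position. From the compounds shown here alone, it is also open whether fluoro would have the same effect alongside the 4-bromo-3-nitrophenyl group of compound 2.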